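Changing One Aromatic Ring on a Shared Core

A few compounds are considered here, and "the series" means these few. Any claim that something is new, unique, unknown or untested is made for them only; others in the source may bear on it.

In a functional assay on A-375 cells (Homo sapiens) for activation, with a stated time of 3 days (a lower number here means that less compound is needed, a higher number that more compound is needed for the effect), compound 2 `O=C(Nc1ccc(-c2cccnc2)cc1)C1CCCN(Cc2ccc(F)c(F)c2)C1` gives 1060 nM and compound 1 `O=C(Nc1ccc(-c2cscn2)cc1)C1CCCN(Cc2ccc(F)c(F)c2)C1` gives 1240 nM, two values within the usual scatter of each other. Compound 3 `O=C(Nc1ccc(-c2nccs2)cc1)C1CCCN(Cc2ccc(F)c(F)c2)C1` changes the same place again: 1,3-thiazol-2-yl in place of pyridin-3-yl on an aromatic carbon. Going by the values given here, no compound carrying 1,3-thiazol-2-yl has been measured yet. Among the compounds with values here, the only measured step, a 1.2-fold lower number from compound 1 to compound 2 (0.07 log units; within the scatter), put pyridin-3-yl in place of 1,3-thiazol-4-yl, so no change beyond the scatter is expected in this assay. The estimated step is a 1.1-fold higher number from compound 2 to compound 3 (0.05 log units; within the scatter). For compound 3 the expected value is 1200 nM, within a range of 550 nM to 2600 nM.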

Compound 3, half-maximal effective concentration: 800 nM
For compound 3 the middle estimate is 1.5-fold (0.18 log units) above the measured one, and the stated range covers the measured number.
By their numbers in this assay, from the lowest: compounds 3, 2 and 1 (each within the scatter of the next).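

Putting 1,3-thiazol-2-yl in place of pyridin-3-yl gives a 1.3-fold lower number from compound 2 to compound 3 (0.12 log units; within the scatter) in this assay, and putting it in place of 1,3-thiazol-4-yl gives a 1.6-fold lower number from compound 1 to compound 3 (0.19 log units; within the scatter) in the same assay. All three aromatic rings at this place, para to a large group, therefore read alike, whether the ring is five-membered or six-membered and whichever way the thiazole is attached. Nothing available explains this result. On these data alone, whether an amine or a carboxylic acid at this place would give a step beyond the scatter remains open.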